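A few compounds are considered here, and "the series" means these few. Any claim that something is new, unique, unknown or untested is made for them only; others in the source may bear on it.

Measured compounds:
compound 1 `c1ccc(CSc2nnc(-c3ccc4c(c3)OCCO4)o2)cc1` gives 32100 nM in a functional assay on HepG2 cells (Homo sapiens) for antiproliferative activity, read by MTT assay, with a stated time of 48 h; on this read-out higher numbers stand for weaker inhibition and lower numbers for stronger inhibition
compound 2 `Brc1ccc(CSc2nnc(-c3ccc4c(c3)OCCO4)o2)cc1` gives 8540 nM in this assay

Within the data shown here, compound 2 stands at the lowest of the two numbers, with compound 1 giving the only other value. Compound 3 `O=[N+]([O-])c1ccc(CSc2nnc(-c3ccc4c(c3)OCCO4)o2)cc1` differs from compound 2 by nitro in place of bromo on an aromatic carbon. Among the measured compounds shown here, the one measured step that bears on this position is a 3.8-fold lower number from compound 1 to compound 2 (0.58 log units; beyond the scatter), a modest change beyond the scatter. For the measured compounds named here, no measured step compares one substituent against another at this place, so compound 3 is expected to stay near compound 2. The expected step is a 1.4-fold lower number from compound 2 to compound 3 (0.15 log units; within the scatter). Compound 3 is therefore estimated at 6000 nM, within a range from 2000 nM to 18000 nM.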

Compound 3, half-maximal inhibitory concentration: 35400 nM
Compound 3: middle estimate off by 5.9-fold (0.77 log units), on the low side; measured number above the stated range.
By their numbers in this assay, from the lowest: compound 2; then compounds 1 and 3 (each within the scatter of the next).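

In this assay this position responds to which substituent it carries, not only to whether one is present, as nitro in place of bromo gives a 4.1-fold higher number from compound 2 to compound 3 (0.62 log units; beyond the scatter) and a number back in the range of the unsubstituted compound. Nitro in place of hydrogen gives a 1.1-fold higher number from compound 1 to compound 3 (0.04 log units; within the scatter) and so leaves no difference beyond the scatter, which means that of the two substituents shown only bromo separates from hydrogen. Nothing at hand accounts for the gap between bromo and nitro. As far as these compounds go, whether chloro, methoxy or an amine at this position would track bromo or nitro remains open.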